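The source may hold more compounds than are shown below. What is called first, only, known or untested is meant among the compounds shown, and "the series" means these compounds.

In a functional assay on cells for agonist activity at Free fatty acid receptor 1 (Homo sapiens), read by calcium flux (a lower number here means that less compound is needed, a higher number that more compound is needed for the effect), the measured compounds stand as follows:

Compound 1, `Cc1cccc(C)c1-c1cccc(COc2ccc(CCC(=O)O)cc2)c1`, gives 8 nM.
Compound 2, `Cc1cccc(C)c1-c1cccc(COc2ccc(CC3SC(=O)NC3=O)s2)c1`, gives 82 nM.

Of these two numbers, compound 2 has the higher one, so more of it is needed for the same effect than of compound 1, and the gap between them lies beyond the usual scatter. Compound 3, `CCO[C@H](CC(=O)O)c1ccc(OCc2cccc(-c3c(C)cccc3C)c2)s1`, keeps the core of compound 2 and differs from it in one place: 2-carboxy-1-ethoxyethyl in place of (2,4-dioxo-1,3-thiazolidin-5-yl)methyl on an aromatic carbon. In words, 2-carboxy-1-ethoxyethyl takes the place of (2,4-dioxo-1,3-thiazolidin-5-yl)methyl on an aromatic carbon. For the measured compounds named here, no measured pair connects these two groups directly, so the size of the step has to be judged from what the two values show. Compound 1, whose side chain also ends in a carboxy group, gives 8 nM, the lower of the two numbers. Compound 3 is therefore expected to move downward, with an estimated step of a 4.1-fold lower number from compound 2 to compound 3 (0.61 log units; beyond the scatter), beyond the scatter. The estimate for compound 3 in this assay is 20 nM, with a likely range from 5 nM to 80 nM.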

Compound 3, half-maximal effective concentration: 50 nM
Compound 3: middle estimate off by 2.5-fold (0.40 log units), on the low side, and the stated range covers the measured number.
By their numbers in this assay, from the lowest: compound 1; then compounds 3 and 2 (each within the scatter of the next).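

In this assay the change gives a 1.6-fold lower number from compound 2 to compound 3 (0.21 log units; within the scatter), so this read-out does not separate the two side chains on the shared core. The position, on an aromatic carbon next to the ring sulfur of a five-membered aromatic ring, holds both (2,4-dioxo-1,3-thiazolidin-5-yl)methyl, which has a five-membered non-aromatic ring, and 2-carboxy-1-ethoxyethyl, which has no ring, and each of these groups has 8 heavy atoms. What lies behind this closeness cannot be told, as no measurement shown here speaks to it.

The compounds shown leave open what the ethoxy branch of 2-carboxy-1-ethoxyethyl contributes on its own, which a plain propanoic acid chain, a methoxy group or an amine at the same carbon would help to show. They also leave open how the mirror-image form at the defined stereocentre of compound 3 would compare, and whether a longer chain carrying the carboxylic acid would still fall within the scatter of compound 3 in this assay.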